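A few compounds are considered here, and "the series" means these few. Any claim that something is new, unique, unknown or untested is made for them only; others in the source may bear on it.

Working notes on the series, read in a functional assay on HepG2 cells (Homo sapiens) for cytotoxicity, read by MTT assay, with a stated time of 48 h; on this read-out lower numbers stand for stronger inhibition and higher numbers for weaker inhibition. Compound 1 (`O=C(CSc1ccccc1)N1N=C(c2cc3ccccc3oc2=O)C[C@@H]1c1ccccc1`) gives 16300 nM, compound 2 (`CC1=NN(C(=O)CSc2ccccn2)[C@@H](c2cc(Br)cc(Br)c2O)C1`) gives 24700 nM, and compound 3 (`CC1=NN(C(=O)CSc2ccccc2)[C@@H](c2cc(Br)cc(Br)c2O)C1`) gives 10400 nM. Compound 3 stands within the scatter of compound 1 and beyond the scatter of compound 2, so it has no clear lead over the whole set.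

Next is compound 4 (`CC1=NN(C(=O)CSc2ccc(Br)cc2)[C@@H](c2cc(Br)cc(Br)c2O)C1`), with the change bromo in place of hydrogen on an aromatic carbon, para to a large group, turning phenylsulfanyl into (4-bromophenyl)sulfanyl. Among the measured compounds shown here, only one measured step touches this aromatic ring on sulfur, namely a 2.4-fold lower number from compound 2 to compound 3 (0.38 log units; beyond the scatter). For the measured compounds named here, that step is modest and swaps the ring itself, and no measured compound tests a substituent on the ring, so it gives only a rough sense of scale. In this assay a small shift towards a lower number is therefore expected, not one clearly beyond the scatter. The expected step is a 1.3-fold lower number from compound 3 to compound 4 (0.11 log units; within the scatter). Compound 4 is estimated at 8000 nM, with an expected range of 3500 nM to 18000 nM.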

Compound 4, half-maximal inhibitory concentration: 6870 nM
Compound 4: middle estimate off by 1.2-fold (0.07 log units), on the high side, within the range that was stated.
By their numbers in this assay, from the lowest: compounds 4, 3, 1 and 2 (each within the scatter of the next, the first and the last beyond it).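

In this assay the first substituent seen on the phenyl ring on sulfur, bromo para to a large group, gives a 1.5-fold lower number from compound 3 to compound 4 (0.18 log units; within the scatter) and so leaves compound 4 not separated from compound 3. The 4-bromophenyl group in place of pyridin-2-yl gives a 3.6-fold lower number from compound 2 to compound 4 (0.56 log units; beyond the scatter) and so sets compound 4, like compound 3, clear of compound 2. No supporting data bear on the cause of either step.

From the compounds shown here alone, whether another group at this position, such as methoxy, an amine or a carboxylic acid, would move the number beyond the scatter from compound 3 remains open. Also open, going by these compounds, is whether bromo at this position would give a comparable step on compound 1, whose core differs from that of compound 3.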